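A few compounds are considered here, and "the series" means these few. Any claim that something is new, unique, unknown or untested is made for them only; others in the source may bear on it.

Compound 1 `CC(=O)OC(C)n1cnc2c(Cl)nc(N)nc21` was tested in a functional assay on FM3A cells (Homo sapiens) for inhibition, with FM3A (Mus musculus) as the target; a lower number here means a stronger inhibitor, a higher number a weaker inhibitor. For compound 1 the outcome is only a limit of the assay, > 500000 nM, so where it truly stands is not known. Compound 2 `CC(=O)OC(C)n1cnc2c(Cl)nc(I)nc21` gives 47000 nM in this assay. Within the data shown here, the one measured step, an at least 10-fold lower number from compound 1 to compound 2 (1.02 log units; beyond the scatter), concerns a different exchange than the one at hand. Compound 1 sits at the limit of > 500000 nM in this assay, at which 1 of the 2 values shown sits, which caps what can be said of any step that starts from it.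

Compound 3 `CC(=O)OC(C)n1cnc2c(S)nc(N)nc21` differs from compound 1 in one place: sulfanyl in place of chloro on an aromatic carbon. Among the measured compounds shown here, no measured step covers a sulfanyl for chloro exchange, and the amino group that compound 2 lost is kept in compound 3. From a starting point that is only a limit, the step from compound 1 to compound 3 is expected to be an at least 1.6-fold lower number from compound 1 to compound 3 (0.22 log units; that floor lies within the scatter), with no direction established beyond the scatter. Compound 3 is therefore estimated at 300000 nM, in a range from 40000 nM to 2000000 nM.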

Compound 3, half-maximal inhibitory concentration: 366000 nM
Estimate against measurement, compound 3: 1.2-fold (0.09 log units) below; low and high end bracket the measured number.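

Compound 3 puts a sulfanyl group where compound 1 carries chloro, next to the ring nitrogen, and with the amino group kept, this exchange gives a measured number in this assay rather than only a limit. The exchange gives an at least 1.3-fold lower number from compound 1 to compound 3 (0.13 log units; that floor lies within the scatter) and so, on the numbers shown, establishes no direction beyond the scatter. From the compounds shown here alone, compound 1 remains a limit of the assay, so this step is only a floor and its true size stays unknown: the limit of > 500000 nM in this assay, at which 1 of the 3 values shown sits.

The compounds shown leave open how this position would respond to other groups, such as a methoxy group, an amine or a longer thioether chain. They also leave open whether sulfanyl at this position, combined with iodo in place of amino as in compound 2, would give a number beyond the scatter of compound 2.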